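Carboxy in place of hydrogen: expected lipophilicity of compound 3

A few compounds are considered here, and "the series" means these few. Any claim that something is new, unique, unknown or untested is made for them only; others in the source may bear on it.

compound 1 `CC(Oc1ccc(Oc2ccc(F)cc2)cc1)C(=O)Cn1nnc(-c2ccccc2)n1` 5.3
compound 2 `CC(Oc1ccc(Oc2ccc(Cl)cc2)cc1)C(=O)Cn1nnc(-c2ccccc2)n1` 6

In a physicochemical assay for lipophilicity, read by HPLC, tested at 5 mM (on this read-out lower numbers stand for lower lipophilicity and higher numbers for higher lipophilicity), compound 1 gives 5.3, the lower of the two numbers measured; compound 2 gives 6. Within the data shown here, the single measured step, a number 0.70 log units higher from compound 1 to compound 2 (beyond the scatter), concerns a halogen swap and does not bear on the change to compound 3 `CC(Oc1ccc(Oc2ccc(F)cc2)cc1)C(=O)Cn1nnc(-c2ccc(C(=O)O)cc2)n1`, which is carboxy in place of hydrogen on an aromatic carbon. Among the measured compounds shown here, no measured step covers this kind of change, so the expectation rests on the change itself and carries a wide range. A downward step, beyond the scatter, is expected in this assay: a number 1.90 log units lower from compound 1 to compound 3 (beyond the scatter). Compound 3 is estimated at 3.4, within 1.8 to 5.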

Compound 3, partition coefficient: 2.7
The estimate for compound 3 lay 0.70 log units above the measured number; measured number inside the range.
By their numbers in this assay, from the lowest: compound 3; then compound 1; then compound 2.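

In this assay the change from phenyl to 4-carboxyphenyl gives a number 2.60 log units lower from compound 1 to compound 3 (beyond the scatter) and so shows what carboxy in place of hydrogen does to this read-out. This is the first change shown at this position, on an aromatic carbon para to a large group, and the step is large, whereas the halogen swap was modest. Nothing available bears on the reason for the size of this step.

Going by these compounds, whether a methyl ester, a primary amide or an amine at the same position would give a step of similar size remains open. So does whether carboxy would give a similar step on the chloro analogue, compound 2.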